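The source may report more compounds than this note shows. Statements on the series, on what has been measured and on what is new or still open speak of the compounds shown alone.

Measured so far in a functional assay on CHO cells for antagonist activity at sphingosine 1-phosphate receptor 2 (Homo sapiens), read by GTPgammaS binding; on this read-out higher numbers stand for weaker inhibition and lower numbers for stronger inhibition:
compound 1 `C[C@@H](C(=O)O)c1nn(Cc2cn3cc(OCC4CC4)c(Cl)cc3n2)c2ccccc2c1=O` gives 253 nM
compound 2 `CCn1nc(CC(=O)Nc2ccc(OC(F)(F)F)c(Cl)c2)c2ccccc2c1=O` gives 473 nM
compound 3 `O=C(O)Cn1nc(Cc2nc3cc(F)c(OCC4CC4)cc3[nH]2)c2ccccc2c1=O` gives 180 nM

Compound 1 lies among these three without any separation: its number and that of compound 3 are within the usual scatter of each other, and so are its number and that of compound 2, so none of the three can be called stronger or weaker than another.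

Among the compounds with values here, compound 4 `COC(C(=O)O)c1nn(Cc2cn3cc(OCC4CC4)c(Cl)cc3n2)c2ccccc2c1=O` keeps the core of compound 1 and changes only one small group: carboxy(methoxy)methyl in place of 1-carboxyethyl on an aromatic carbon. The acid remains, and only one carbon atom is exchanged for an oxygen atom beside it. Within the data shown here, nothing among the measured compounds probes such an exchange. Only a small step in this assay is expected, with no clear direction beyond the scatter, a 1.4-fold higher number from compound 1 to compound 4 (0.14 log units; within the scatter). Compound 4 is therefore estimated at 350 nM, within 120 nM to 1000 nM.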

Compound 4, half-maximal inhibitory concentration: 58 nM
For compound 4 the middle estimate is 6.0-fold (0.78 log units) above the measured one, outside the stated range (below it).
By their numbers in this assay, from the lowest: compound 4; then compounds 3, 1 and 2 (each within the scatter of the next, the first and the last beyond it).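

In this assay, carboxy(methoxy)methyl in place of 1-carboxyethyl on this aromatic carbon gives a 4.4-fold lower number from compound 1 to compound 4 (0.64 log units; beyond the scatter) and so shows that a small edit to this side chain can carry the number beyond the scatter. The entering group also lists no defined stereocentre, so the added oxygen and the lost stereocentre cannot be told apart here. No measurement at hand explains the shift.

Still open, as far as these compounds go, is whether the methoxy group itself matters, or whether a hydroxy group, an ethoxy group or an amine on the same carbon would give a similar number. From the compounds shown here alone, how the two mirror-image forms of compound 4 compare also remains unknown.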